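Amino-to-hydroxy swap on the propargylic carbon of compound 3

A few compounds are considered here, and "the series" means these few. Any claim that something is new, unique, unknown or untested is made for them only; others in the source may bear on it.

Compound 1 `COc1ccc(C#CC(C)(C)N)cc1-c1[nH]nc2nc(Nc3ccc(F)cc3F)ccc12` gives 95% in an in vivo ADME assay on the whole organism for pharmacokinetics, with Rattus norvegicus as the target; on this read-out higher numbers stand for higher oral bioavailability and lower numbers for lower oral bioavailability. Among the measured compounds shown here, compound 2 `COc1ccc(CCC(C)(C)N)cc1-c1[nH]nc2nc(Nc3ccc(F)cc3F)ccc12` gives 20%, and the only step between compounds differing in one place is a number 75 percentage points lower from compound 1 to compound 2 (beyond the scatter). Compound 3 `COc1ccc(C#CC(C)(C)N)cc1-c1[nH]nc2nc(Nc3ccc(F)cc3F)cnc12` gives 9%, the lowest of the three numbers, with compound 2 as its nearest neighbour and compound 1 furthest away.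

Compound 4 `COc1ccc(C#CC(C)(C)O)cc1-c1[nH]nc2nc(Nc3ccc(F)cc3F)cnc12` differs from compound 3 only by hydroxy in place of amino on a saturated chain carbon bound to two saturated chain carbons and a triple-bonded carbon. For the measured compounds named here, no measured pair shows this exchange; the single measured step concerns the chain linker on a different part of the molecule and says nothing about a heteroatom swap at the tertiary carbon. With compound 3 already near the bottom of the read-out, the room for a further drop is small, and nothing measured argues for a rise. The expected change is therefore a number 6 percentage points higher from compound 3 to compound 4 (within the scatter), not beyond the scatter. The estimate for compound 4 in this assay is 15%, within a range from 4% to 35%.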

Compound 4, oral bioavailability: 22%
For compound 4 the middle estimate is 7 percentage points below the measured one; the measured number falls inside the stated range.
By their numbers in this assay, from the lowest: compound 3; then compounds 2 and 4 (each within the scatter of the next); then compound 1.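

In this assay the exchange of amino for hydroxy on a saturated chain carbon bound to two saturated chain carbons and a triple-bonded carbon gives a number 13 percentage points higher from compound 3 to compound 4 (beyond the scatter) and so shows that the read-out responds to this single atom, with the rest of the molecule unchanged. The size of the step is modest, and it arises between two groups that match in hydrogen-bond donors, hydrogen-bond acceptors and net charge, so those counts do not separate them. No measured property bears on this step, and its cause remains unassigned.

The compounds shown leave open whether the same exchange carries over to the core of compound 1. They also leave open whether a methoxy or methylamino group on this carbon would fall in line with hydroxy or with amino.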